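From Thiophen-3-yl to 4-Chlorophenyl: Expected Solubility

This account rests on a few compounds, and the source may have more. Where it says the series, first, only, none or still open, it means among the compounds named here.

Compound 1 `CN1CCC(C(=O)N2Cc3c(NC(=O)c4ccsc4)n[nH]c3C2(C)C)CC1` in a physicochemical assay for solubility, at pH 7 (a higher number here means a more soluble compound, a lower number a less soluble compound), gives a limit, > 225000 nM
Compound 2 `CN1CCC(C(=O)Nc2n[nH]c3c2CN(C(=O)C(C)(C)C)C3(C)C)CC1` gives a limit, > 225000 nM
Compound 3 `CC(C)(C)C(=O)N1Cc2c(NC(=O)c3cccnc3)n[nH]c2C1(C)C` gives 207000 nM

Compound 1 stands at the top of what this assay can report: its result is a limit rather than a number. Compound 2 likewise sits at a limit. Compound 3 gives a plain number, close to that ceiling. Most of the data therefore crowd at the limit of > 225000 nM in this assay, at which 2 of the 3 values shown sit. Going by the values given here, the only measured step between compounds that differ in one place is an at least 1.0-fold lower number from compound 2 to compound 3 (0.03 log units; that floor lies within the scatter), a change that left the number essentially where it was.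

Compound 4 `CN1CCC(C(=O)N2Cc3c(NC(=O)c4ccc(Cl)cc4)n[nH]c3C2(C)C)CC1` has not been measured. It differs from compound 1 in one place: 4-chlorophenyl in place of thiophen-3-yl on a carbonyl carbon. Among the compounds with values here, no measured step involves this same exchange; the one step that was measured concerned a different pair of groups on a carbonyl carbon and stayed within the scatter, so it offers little direct guidance. The starting point, the value of compound 1, is known only as a limit, which makes the true gap uncertain.

The expected outcome for compound 4 is a somewhat lower number, an at least 1.6-fold lower number from compound 1 to compound 4 (0.20 log units; that floor lies within the scatter). The estimate for compound 4 is 140000 nM, with a range from 40000 nM to 225000 nM, and a real chance that the assay again reports only its limit.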

Compound 4, solubility: > 225000 nM
Compound 4: no number, only a limit (the forecaster's own chance of this, stated with the estimate: 35%); middle value at least 1.6-fold (0.20 log units) away from the limit.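

Compound 1 and compound 4 both return only a limit in this assay, so the step between them, 4-chlorophenyl in place of thiophen-3-yl, cannot be read: the limit of > 225000 nM in this assay, at which 3 of the 4 values shown sit.

The compounds shown leave open how far apart compound 1 and compound 4 truly lie in this assay, and whether this exchange changes the number at all.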